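From iodo to trifluoromethyl in an antiproliferative series

This account rests on a few compounds, and the source may have more. Where it says the series, first, only, none or still open, it means among the compounds named here.

compound 1 `C#C[C@@]1(O)[C@@H](CO)O[C@@H](n2cnc3c(-c4ccc(F)cc4)ncnc32)[C@@H]1O` gives > 250000 nM, a limit and not a number
compound 2 `C#C[C@@]1(O)[C@@H](CO)O[C@@H](n2cc(Br)c3c(N)ncnc32)[C@@H]1O` gives 28 nM
compound 3 `C#C[C@@]1(O)[C@@H](CO)O[C@@H](n2cc(I)c3c(N)ncnc32)[C@@H]1O` gives 56 nM

Within the data shown here, in a functional assay on L1210 cells (Mus musculus) for antiproliferative activity, read by cell counting, with a stated time of 48 h (on this read-out higher numbers stand for weaker inhibition and lower numbers for stronger inhibition), compound 3 (56 nM) lies within the scatter of compound 2 (28 nM), and these are the only two numbers in hand. The next structure, compound 4 `C#C[C@@]1(O)[C@@H](CO)O[C@@H](n2cc(C(F)(F)F)c3c(N)ncnc32)[C@@H]1O`, carries trifluoromethyl in place of iodo on an aromatic carbon. Among the measured compounds shown here, one measured step bears on this, iodo in place of bromo on an aromatic carbon, a 2.0-fold higher number from compound 2 to compound 3 (0.30 log units; within the scatter), which stays within the scatter. For the measured compounds named here, no measured step brings in trifluoromethyl, so a wide range is kept. A step beyond the scatter is not expected, and the estimated step is (a 1.8-fold higher number from compound 3 to compound 4 (0.25 log units; within the scatter)). Compound 4 is expected at about 100 nM (estimated range 20 nM to 500 nM).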

Compound 4, half-maximal inhibitory concentration: 110 nM
Compound 4: middle estimate off by 1.1-fold (0.04 log units), on the low side; the range from low to high includes it.
By their numbers in this assay, from the lowest: compounds 2, 3 and 4 (each within the scatter of the next, the first and the last beyond it). At a limit, above all of these: compound 1.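

At this position on the five-membered aromatic ring, trifluoromethyl, with 4 heavy atoms, stands in place of the single iodine, and the number stays within the scatter in this assay (a 2.0-fold higher number from compound 3 to compound 4 (0.29 log units; within the scatter)). Against bromo, however, trifluoromethyl gives a modest step beyond the scatter (a 3.9-fold higher number from compound 2 to compound 4 (0.59 log units; beyond the scatter)), so these two groups are told apart while iodo is told apart from neither. Nothing measured here gives a cause for either step. Going by these compounds, whether an amine, a nitrile or a longer chain at this position would stay in this range remains open.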